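The compounds below may be only part of what the source reports. "The series", "measured", "known", "first", "only" and "open" are said of these compounds alone.

The measured compounds:
compound 1, `COc1ccc(C2C(C#N)=C(N)N(c3cc(OC)c(OC)c(OC)c3)C3=C2C(=O)CC(C)(C)C3)cc1`, with 0% in a functional assay on Ehrlich cells (Mus musculus) for cytotoxicity, tested at 10 ug/mL; a higher number here means a stronger effect of the compound at the concentration tested, a lower number a weaker effect
compound 2, `COc1cc(N2C(N)=C(C#N)C(c3ccccc3O)C3=C2CC(C)(C)CC3=O)cc(OC)c1OC`, with 0% in this assay

Compound 1 stands level with compound 2 at the digits shown: neither gives a measurable effect, and the step of no change at the digits printed from compound 1 to compound 2 (within the scatter) lies within the scatter. The unmeasured compound 3, `COc1cc(N2C(N)=C(C#N)C(c3ccc(O)cc3)C3=C2CC(C)(C)CC3=O)cc(OC)c1OC`, arises from compound 1 by one change: hydrogen in place of methyl on an oxygen on an aromatic ring. For the measured compounds named here, only one measured step bears on this, and it sits on the same aromatic ring while exchanging a different group: no change at the digits printed from compound 1 to compound 2 (within the scatter). That step shows no movement, and compound 1 and compound 2 both sit at the bottom of the scale. Nothing in these data gives reason to expect the exchange of methyl for hydrogen to move the read-out. The step of no change at the digits printed from compound 1 to compound 3 (within the scatter) is therefore expected to stay within the scatter. Compound 3 is estimated at 0%, with a range from 0% to 10%.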

Compound 3, a percentage reported as activity, at one concentration (the size of the read-out at that concentration, not a potency): 10%
Beside the measured number, compound 3's estimate is 10 percentage points below it, within the range that was stated.
By their numbers in this assay, from the lowest: compounds 1, 2 and 3 (each within the scatter of the next).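

Exchanging methyl for hydrogen on the oxygen, methoxy to hydroxy on the 4-methoxyphenyl group, gives a number 10 percentage points higher from compound 1 to compound 3 (within the scatter) in this assay and so tests the group on that oxygen directly. Comparing the two hydroxyphenyl groups, 4-hydroxyphenyl in place of 2-hydroxyphenyl gives a number 10 percentage points higher from compound 2 to compound 3 (within the scatter) and so shows that, at this concentration, these two placements of the hydroxy group cannot be told apart. No measurement offers an explanation for these small numbers.

Still open, from the compounds shown here alone, is whether an amine or a carboxylic acid in place of the hydroxy group, or an ethoxy group in place of the methoxy group, would give a step beyond the scatter. A read-out at one concentration also leaves open how these compounds would compare at other concentrations.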